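The compounds below may be only part of what the source reports. "The series", "measured", "known", "first", "only" and "open" are said of these compounds alone.

Three compounds have been measured in a functional assay (Homo sapiens) for inhibition; on this read-out lower numbers stand for stronger inhibition and higher numbers for weaker inhibition:

- compound 1 `CSc1ccccc1CSc1nc(-c2ccc(F)cc2)c(-c2ccncc2)[nH]1`: 6700 nM
- compound 2 `C[S+]([O-])c1cc(CSc2nc(-c3ccc(F)cc3)c(-c3ccncc3)[nH]2)ccc1O`: 2300 nM
- compound 3 `CSc1ccc(O)c(CSc2nc(-c3ccc(F)cc3)c(-c3ccncc3)[nH]2)c1`: 740 nM

Compound 3 has the lowest number of the three, and its gaps to both others lie beyond the scatter. The next compound, compound 4 `CSc1cc(Cl)cc(CSc2nc(-c3ccc(F)cc3)c(-c3ccncc3)[nH]2)c1O`, is not yet measured. It differs from compound 3 by 5-chloro-2-hydroxy-3-(methylsulfanyl)phenyl in place of 2-hydroxy-5-(methylsulfanyl)phenyl on a saturated chain carbon bound to a sulfur, which puts 5-chloro-2-hydroxy-3-(methylsulfanyl)phenyl in place of 2-hydroxy-5-(methylsulfanyl)phenyl on a saturated chain carbon bound to a sulfur.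

Two measured steps changed this same group. One is a 9.1-fold lower number from compound 1 to compound 3 (0.96 log units; beyond the scatter), and the other is a 3.1-fold lower number from compound 2 to compound 3 (0.49 log units; beyond the scatter). Both are modest, so changes here have so far moved the number only moderately. Going by the values given here, compound 4 keeps the hydroxy and methylsulfanyl groups of compound 3, but no measured compound carries a chlorine, and none has this arrangement of groups. A step beyond the scatter is therefore not expected in this assay, and no direction is firmly indicated. The expected step is a 1.5-fold lower number from compound 3 to compound 4 (0.17 log units; within the scatter). For compound 4 the estimated value is 500 nM, with an expected range of 150 nM to 1700 nM.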

Compound 4, half-maximal inhibitory concentration: 640 nM
Beside the measured number, compound 4's estimate is 1.3-fold (0.11 log units) below it; the range from low to high includes it.
By their numbers in this assay, from the lowest: compounds 4 and 3 (each within the scatter of the next); then compound 2; then compound 1.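

In this assay compound 4 cannot be told apart from compound 3, with a 1.2-fold lower number from compound 3 to compound 4 (0.06 log units; within the scatter), so this position takes the 5-chloro-2-hydroxy-3-(methylsulfanyl)phenyl group in place of 2-hydroxy-5-(methylsulfanyl)phenyl with no step beyond the scatter. Going by these compounds alone, the new group also keeps the distance from the other two compounds, with a 3.6-fold lower number from compound 2 to compound 4 (0.56 log units; beyond the scatter) and with a 10-fold lower number from compound 1 to compound 4 (1.02 log units; beyond the scatter), and the latter is the first step at this position to count as large. Nothing on hand explains these numbers.

Going by these compounds, compound 4 carries the chlorine and the new arrangement of the methylsulfanyl and hydroxy groups together, so the separate contribution of each remains unknown, and the two could be offsetting each other. On these data alone, whether an amine or a carboxylic acid in the place of the chlorine would move the number beyond the scatter also remains open.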